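The compounds below may be only part of what the source reports. "The series", "measured", "known", "first", "only" and "open" are said of these compounds alone.

Compound 1 `COc1ccc(F)cc1CNCCCNc1ccnc2cc(C3CCCCC3)ccc12` stands at the low end of the three numbers in an ADME assay for permeability, using PAMPA, with a stated time of 30 min, at pH 7.4 (on this read-out lower numbers stand for lower permeability and higher numbers for higher permeability), where compound 1 gives 23 10^-6 cm/s. Compound 3 `c1coc(CNCCCNc2ccnc3cc(C4CCCCC4)ccc23)c1` gives 23 10^-6 cm/s in this assay, and no change at the digits printed from compound 1 to compound 3 (within the scatter), so the two sit together and neither can be called the lower. Going by the values given here, compound 2 `COc1ccc(Oc2ccc3c(NCCCNCc4ccco4)ccnc3c2)cc1` gives 317 10^-6 cm/s in this assay, the only number set well apart. Compound 4 `COc1ccc(F)cc1CNCCCNc1ccnc2cc(-c3ccc(C(C)(C)C)cc3)ccc12` is not yet measured; it differs from compound 1 by 4-(tert-butyl)phenyl in place of cyclohexyl on an aromatic carbon. Among the compounds with values here, the one measured step at the same carbon of the shared core is the exchange of 4-methoxyphenoxy for cyclohexyl, which gave a 14-fold lower number from compound 2 to compound 3 (1.14 log units; beyond the scatter); read the other way, it shows an aromatic group at this carbon carrying a higher number, though 4-(tert-butyl)phenyl is not 4-methoxyphenoxy, so the comparison is loose. Compound 4 is therefore expected to move upward, with a 2.0-fold higher number from compound 1 to compound 4 (0.29 log units; within the scatter) as the expected step. The estimate for compound 4 is 45 10^-6 cm/s, within a range of 12 10^-6 cm/s to 160 10^-6 cm/s.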

Compound 4, apparent permeability: 237 10^-6 cm/s
Estimate against measurement, compound 4: 5.3-fold (0.72 log units) below, and the stated range ends below it.
By their numbers in this assay, from the lowest: compounds 1 and 3 (each within the scatter of the next); then compounds 4 and 2 (each within the scatter of the next).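

In this assay, 4-(tert-butyl)phenyl in place of cyclohexyl on this aromatic carbon gives a 10-fold higher number from compound 1 to compound 4 (1.01 log units; beyond the scatter). This shows a large step at this carbon with 5-fluoro-2-methoxyphenyl on the chain, whereas the only earlier step here, a 14-fold lower number from compound 2 to compound 3 (1.14 log units; beyond the scatter), had furan-2-yl on the chain; in both pairs the compound carrying cyclohexyl has the lower number, and no compound shown goes against this. The data shown offer nothing that explains the rise.

The compounds shown leave open whether a plain phenyl group, without the tert-butyl group, would give a step of this size, and how an amine or a carboxylic acid on this carbon would read. They also leave open whether 4-(tert-butyl)phenyl would give a similar step with furan-2-yl on the chain.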